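Isobutyl in Place of Isopropyl on the Aminoacyl Sulfamate

The compounds below may be only part of what the source reports. "The series", "measured", "known", "first", "only" and "open" are said of these compounds alone.

Measured compounds:
compound 1 `CC(C)C[C@H](N)C(=O)NS(=O)(=O)OC[C@H]1OC[C@@H](n2cnc3c(N)ncnc32)[C@H](O)[C@@H]1O` with 1000 nM
compound 2 `CC(C)[C@H](N)C(=O)NS(=O)(=O)OC[C@H]1O[C@@H](n2cnc3c(N)ncnc32)[C@H](O)[C@@H]1O` with 5600 nM
compound 3 `Nc1ncnc2c1ncn2[C@@H]1CO[C@H](COS(=O)(=O)NC(=O)[C@@H]2CCCN2)[C@@H](O)[C@H]1O` with 750 nM

In a functional assay on PBMC cells (Homo sapiens) for inhibition (on this read-out lower numbers stand for stronger inhibition and higher numbers for weaker inhibition), compound 2 gives the highest of the three numbers. Compound 1 sits beyond the scatter on the lower side, and compound 3 further still, so compound 2 is the weakest inhibitor of the set. Between compound 1 and compound 3 the step of a 1.3-fold lower number from compound 1 to compound 3 (0.12 log units; within the scatter) is small.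

The unmeasured compound 4 `CC(C)C[C@H](N)C(=O)NS(=O)(=O)OC[C@H]1O[C@@H](n2cnc3c(N)ncnc32)[C@H](O)[C@@H]1O` keeps the core of compound 2 and differs from it in one place: isobutyl in place of isopropyl on a saturated chain carbon bound to an amine nitrogen and a carbonyl carbon.

For the measured compounds named here, no measured pair isolates this particular change. Compound 1 carries the same 1-amino-3-methylbutyl group as compound 4, but on a different core. Set against compound 2, the value of compound 1, 1000 nM, only shows that a compound with the isobutyl group reached a lower number than the isopropyl compound, without separating the two differences. Going by the values given here, the one step that was measured, from compound 1 to compound 3, concerns a different exchange and lies within the scatter. The expectation for compound 4 is therefore a step toward lower numbers, expressed as a 4.7-fold lower number from compound 2 to compound 4 (0.67 log units; beyond the scatter), with wide uncertainty. Compound 4 is estimated at 1200 nM, within 200 nM to 5600 nM.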

Compound 4, half-maximal inhibitory concentration: 1100 nM
Estimate against measurement, compound 4: 1.1-fold (0.04 log units) above; measured number inside the range.
By their numbers in this assay, from the lowest: compounds 3, 1 and 4 (each within the scatter of the next); then compound 2.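

With the core of compound 2 held fixed, isobutyl in place of isopropyl now stands alone, and in this assay the exchange gives a 5.1-fold lower number from compound 2 to compound 4 (0.71 log units; beyond the scatter) with no other difference in the structure. The earlier gap between compound 2 and compound 1 mixed this exchange with a difference in the core, whereas this pair shows that the side chain alone, 4 carbon atoms in place of 3 on a saturated chain carbon bound to an amine nitrogen and a carbonyl carbon, is enough to move the number beyond the scatter. Nothing at hand tells what lies behind this step.

From the compounds shown here alone, on this core the position is described by only two side chains, so the pair gives one step and no trend, and it remains open whether a longer chain such as n-pentyl, a benzyl group or a carboxylic acid at the same place would lower the number further, leave it unchanged or raise it. Going by these compounds, it also remains open whether the exchange of isopropyl for isobutyl gives a step of the same size on the core of compound 1 or on any other core.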